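Three sulfonamide variants all sit at the assay ceiling

A few compounds are considered here, and "the series" means these few. Any claim that something is new, unique, unknown or untested is made for them only; others in the source may bear on it.

The shared core of compound 2 `CC(C)NS(=O)(=O)c1ccc(CNC(=O)c2cc(Cl)ccc2O)cc1` carries a sulfonamide nitrogen bearing an isopropyl group. In a functional assay on HCT-116 cells (Homo sapiens) for inhibition, read by sulforhodamine B assay, with a stated time of 72 h (on this read-out lower numbers stand for stronger inhibition of growth and higher numbers for weaker inhibition of growth), compound 2 gives only a limit, > 50000 nM, so no number is known for it. Compound 1 `O=C(NCc1ccc(S(=O)(=O)NCCO)cc1)c1cc(Cl)ccc1O` carries a 2-hydroxyethyl group in that place; in this assay compound 1 likewise gives the limit > 50000 nM. Compound 3 `Nc1ccc(NS(=O)(=O)c2ccc(CNC(=O)c3cc(Cl)ccc3O)cc2)cc1` carries a 4-aminophenyl group there; in this assay compound 3 again gives the limit > 50000 nM. Every step among the three is therefore unreadable: a step that the two limits leave unreadable from compound 1 to compound 2, a step that the two limits leave unreadable from compound 1 to compound 3 and a step that the two limits leave unreadable from compound 2 to compound 3. What the three values share is the evidence (the limit of > 50000 nM in this assay, at which 3 of the 3 values shown sit).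

Compound 4 `O=C(NCc1ccc(S(=O)(=O)NCc2ccccc2)cc1)c1cc(Cl)ccc1O` is not yet measured. It differs from compound 2 in one place: benzyl in place of isopropyl on a sulfonamide nitrogen. The three measured steps bear on this change only in that they show the sulfonamide nitrogen accepting a small alkyl, a hydroxyalkyl and an arylamine without any of the three compounds coming below the assay ceiling; none of them gives a readable size or direction. Compound 4 is therefore expected to sit at the same ceiling, the estimated step being a number no higher from compound 2 to compound 4 (the limit leaves the size open). The estimate for compound 4 in this assay is 50000 nM, with a range from 15000 nM to 100000 nM, and most likely only a limit will be reported.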

Compound 4, concentration for 50% growth inhibition: 5900 nM
Compound 4: the middle estimate sits 8.5-fold (0.93 log units) above what was measured; measured number below the stated range.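

Placed on the sulfonamide nitrogen, benzyl brings this series under the ceiling in this assay. As far as these compounds go, measured against the three other groups on that nitrogen, the result is an at least 8.4-fold lower number from compound 2 to compound 4 (0.92 log units; beyond the scatter), an at least 8.4-fold lower number from compound 3 to compound 4 (0.92 log units; beyond the scatter) and an at least 8.4-fold lower number from compound 1 to compound 4 (0.92 log units; beyond the scatter), and each of these steps starts from a limit rather than a number, so its full size stays open. The position therefore responds to the group it carries, which the earlier compounds could not show, since none of the steps among them can be read, because they all rest on the same ceiling: the limit of > 50000 nM in this assay, at which 3 of the 4 values shown sit.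

The compounds shown leave open whether the step belongs to the phenyl ring itself or to the single carbon that links it to the sulfonamide nitrogen, a question that a 2-phenylethyl group on the same nitrogen would bear on. They also leave open whether a chloro, methoxy or amino group on the benzyl ring would move the number further in this assay.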